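Trimming the sulfonamide chain of a weak pyrazolyl analogue

The source may report more compounds than this note shows. Statements on the series, on what has been measured and on what is new or still open speak of the compounds shown alone.

Measured compounds:
Compound 1, `CCCNS(=O)(=O)c1ccc(Nc2ncc3c(n2)N(C2CCCC2)[C@H](CC)C(=O)N3C)cc1`: 344 nM
Compound 2, `CCC1C(=O)N(C)c2cnc(Nc3ccc(S(=O)(=O)NCCCO)cc3)nc2N1c1ccn(C)n1`: 21600 nM
Compound 3, `CCCCNC(=O)c1ccc2c(ccn2-c2ncc3c(n2)N(c2ccn(C)n2)C(CC)C(=O)N3C)c1`: 8990 nM

In a functional assay on MCF7 cells (Homo sapiens) for antiproliferative activity, read by CCK-8 assay, with a stated time of 72 h (on this read-out lower numbers stand for stronger inhibition of growth and higher numbers for weaker inhibition of growth), compound 1 gives 344 nM, the lowest number of the three. Compound 3 gives 8990 nM in this assay. Compound 2, with a (3-hydroxypropyl)sulfamoyl group on its aniline, gives 21600 nM in this assay, the highest number of the set; it stands beyond the scatter from compound 3 and far beyond the scatter from compound 1, so it is the weakest of the three.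

Compound 4, `CCC1C(=O)N(C)c2cnc(Nc3ccc(S(=O)(=O)NC)cc3)nc2N1c1ccn(C)n1`, has not yet been measured in this assay. It differs from compound 2 in one place: hydrogen in place of 2-hydroxyethyl on a saturated chain carbon bound to a sulfonamide nitrogen. Among the compounds with values here, no pair of measured compounds shows this change, so the size of the step is open. Because compound 2 sits at 21600 nM and the change removes only a short hydroxy-bearing chain, a modest step toward stronger inhibition is expected, and it may well stay within the scatter. The step from compound 2 to compound 4 is estimated at a 1.5-fold lower number from compound 2 to compound 4 (0.19 log units; within the scatter) in this assay. Compound 4 is expected to give 14000 nM in this assay, within a range from 5000 nM to 40000 nM.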

Compound 4, concentration for 50% growth inhibition: 3750 nM
Compound 4: middle estimate off by 3.7-fold (0.57 log units), on the high side; measured number outside the range, below it.
By their numbers in this assay, from the lowest: compound 1; then compound 4; then compound 3; then compound 2.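

In this assay, replacing the (3-hydroxypropyl)sulfamoyl group with methylsulfamoyl gives a 5.8-fold lower number from compound 2 to compound 4 (0.76 log units; beyond the scatter), the first sign from a matched pair that the group on the sulfonamide nitrogen matters to this read-out. With the pyrazolyl core and the rest of the structure unchanged, the hydroxy-bearing chain is not needed for growth inhibition here, since the shorter methylsulfamoyl group of compound 4 gives the lower number, though this rests on one pair alone. Nothing in the data gives a reason for this step.

The pair cannot separate the loss of the hydroxy group from the shortening of the chain, and a plain propyl chain on this core would be needed to tell the two apart, as compound 1 carries such a chain but also differs elsewhere. From the compounds shown here alone, it also remains open how a primary sulfonamide, an ethyl group or a chain ending in an amine or a carboxylic acid would compare at this place on the sulfonamide nitrogen.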